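This account rests on a few compounds, and the source may have more. Where it says the series, first, only, none or still open, it means among the compounds named here.

Measured compounds:
compound 1 `N=C(NCCCc1c[nH]cn1)NCCC(c1ccc(F)cc1)c1ccccn1`: 0.8
compound 2 `N=C(NCCCc1c[nH]cn1)NCCC(c1ccc(Br)cc1)c1ccccn1`: 0.4
compound 3 `N=C(NCCCc1c[nH]cn1)NCCC(c1ccc(C(F)(F)F)cc1)c1ccccn1`: 0.9

All three numbers come from a functional assay on muscle tissue for agonist activity at histamine H2 receptor (Cavia porcellus); on this read-out higher numbers stand for larger maximal responses and lower numbers for smaller maximal responses. Compound 1 stands second highest of the three; its nearest neighbour is compound 3, reached by a number 0.10 higher from compound 1 to compound 3 (within the scatter), while the furthest is compound 2, reached by a number 0.40 lower from compound 1 to compound 2 (beyond the scatter). The remaining step, a number 0.50 higher from compound 2 to compound 3 (beyond the scatter), completes the set.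

Compound 4 `N=C(NCCCc1c[nH]cn1)NCCC(c1ccc(F)cc1)c1cccnc1` differs from compound 1 by pyridin-3-yl in place of pyridin-2-yl on a saturated chain carbon bound to an aromatic carbon and a saturated chain carbon. Going by the values given here, none of the measured steps touches this part of the core: every one of them exchanges the group on an aromatic carbon of the other ring, so none bears directly on the change from compound 1 to compound 4. Among the compounds with values here, two of the three measured steps were large, which shows that this assay can move strongly on a single exchange, but there is no measured example of moving the ring nitrogen. Without such a precedent the expectation for compound 4 is a step of a number 0.10 lower from compound 1 to compound 4 (within the scatter) from compound 1, that is, no change beyond the scatter, held with a wide range. Compound 4 is estimated at 0.7, between 0.4 and 0.95.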

Compound 4, intrinsic activity: the largest response reached, as a fraction of the reference agonist's: 0.8
Compound 4: the middle estimate sits 0.10 below what was measured; the measured number falls inside the stated range.
By their numbers in this assay, from the lowest: compound 2; then compounds 1, 4 and 3 (each within the scatter of the next).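

In this assay, the step at the saturated chain carbon bound to an aromatic carbon and a saturated chain carbon, pyridin-3-yl in place of pyridin-2-yl, reads no change at the digits printed from compound 1 to compound 4 (within the scatter). Going by these compounds alone, this is the first read on this place, and the maximal response holds through the exchange, unlike the halogen exchange on the aromatic carbon that gave a number 0.40 lower from compound 1 to compound 2 (beyond the scatter). No supporting data bear on this outcome.

Open, as far as these compounds go, is whether pyridin-4-yl or a plain phenyl at this place would also hold the response in this assay. Also open, from the compounds shown here alone, is whether the pyridin-3-yl exchange would read the same with bromo or trifluoromethyl in place of fluoro on the aromatic carbon.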